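Pyrrolidin-1-yl and 4-methylpiperazin-1-yl in the series

This account rests on a few compounds, and the source may have more. Where it says the series, first, only, none or still open, it means among the compounds named here.

Values measured in a functional assay on MCF7 cells (Homo sapiens) for antiproliferative activity, read by MTT assay, with a stated time of 48 h (on this read-out lower numbers stand for stronger inhibition and higher numbers for weaker inhibition), so far:
Compound 1 `CN1CCN(CC(=O)Nc2ccc3ncnc(Nc4cccc(Cl)c4)c3c2)CC1` gives > 100000 nM as a limit
Compound 2 `O=C(CN1CCCC1)Nc1ccc2ncnc(Nc3cccc(Br)c3)c2c1` gives 12000 nM as a number

Within the data shown here, compound 2 at 12000 nM holds the only number. Compound 1 sits at the limit of > 100000 nM in this assay, at which 1 of the 2 values shown sits, and gives no number.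

Compound 3 `CN1CCN(CC(=O)Nc2ccc3ncnc(Nc4cccc(Br)c4)c3c2)CC1` is not yet measured. It carries 4-methylpiperazin-1-yl in place of pyrrolidin-1-yl on a saturated chain carbon bound to a carbonyl carbon, with 4-methylpiperazin-1-yl in place of pyrrolidin-1-yl on a saturated chain carbon bound to a carbonyl carbon as the counted difference. No measured step sizes this change directly.

The expectation leans on compound 1, which also carries 4-methylpiperazin-1-yl and gives > 100000 nM as a limit of the assay. In this assay the expected step of a 2.9-fold higher number from compound 2 to compound 3 (0.46 log units; beyond the scatter) is a moderate one towards weaker inhibition, estimated to lie beyond the scatter. For compound 3 the estimated value is 35000 nM with an expected range from 12000 nM to 100000 nM as its bounds.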

Compound 3, half-maximal inhibitory concentration: 10000 nM
For compound 3 the middle estimate is 3.5-fold (0.54 log units) above the measured one, outside the stated range (below it).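

In this assay, the exchange of pyrrolidin-1-yl for 4-methylpiperazin-1-yl on a saturated chain carbon bound to a carbonyl carbon now has a size: a 1.2-fold lower number from compound 2 to compound 3 (0.08 log units; within the scatter), so the two compounds cannot be told apart here. With 4-methylpiperazin-1-yl held fixed, bromo in place of chloro on an aromatic carbon gives an at least 10-fold lower number from compound 1 to compound 3 (1.00 log units; beyond the scatter), so 4-methylpiperazin-1-yl alone does not account for the result of compound 1. Compound 1 is a limit of the assay and not a number: the limit of > 100000 nM in this assay, at which 1 of the 3 values shown sits.

As far as these compounds go, whether the chloro to bromo step also holds with pyrrolidin-1-yl on the chain stays open, as does the outcome with fluoro or iodo on that aromatic carbon. Morpholin-4-yl or dimethylamino on the saturated chain carbon, or a longer chain carrying either amine, also remains open.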